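This account rests on a few compounds, and the source may have more. Where it says the series, first, only, none or still open, it means among the compounds named here.

Measured in a functional assay on PBMC cells (Homo sapiens) for inhibition, read by HTRF, with stated times of 15 min and 24 h; on this read-out higher numbers stand for weaker inhibition and lower numbers for stronger inhibition:
- compound 1 `O=C(Nc1ccc2c(c1)B(O)OC2)c1ccccc1C(F)(F)F`: 4400 nM
- compound 2 `O=C(Nc1ccc2c(c1)B(O)OC2)c1ccccc1F`: > 10000 nM (a limit)
- compound 3 `O=C(Nc1ccc2c(c1)B(O)OC2)c1ccccc1Cl`: > 100000 nM (a limit)

Compound 3 stands at > 100000 nM, which is only a limit. Its true number in this assay is therefore unknown. The next compound, compound 4 `Cc1ccccc1C(=O)Nc1ccc2c(c1)B(O)OC2`, keeps the shared core and carries methyl in place of chloro on an aromatic carbon.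

For the measured compounds named here, no measured step covers this exact swap, so the nearest evidence comes from the same spot on the molecule. Replacing trifluoromethyl with chloro gave an at least 22-fold higher number from compound 1 to compound 3 (1.35 log units; beyond the scatter), a large step. Replacing trifluoromethyl with fluoro gave an at least 2.2-fold higher number from compound 1 to compound 2 (0.35 log units; beyond the scatter), an at least modest one. Between the two limits, the comparison gives a step that the two limits leave unreadable from compound 2 to compound 3.

Compound 4 also lacks trifluoromethyl, so it is expected to stay weak, though probably with a lower number than the limit of compound 3. The expected change is an at least 5.0-fold lower number from compound 3 to compound 4 (0.69 log units; beyond the scatter). For compound 4 the estimated value is 20000 nM, with an expected range of 4000 nM to 100000 nM.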

Compound 4, half-maximal inhibitory concentration: > 100000 nM
Compound 4 ended at the assay's limit; the forecaster's own chance of this, stated with the estimate: 55%; at least 5.0-fold (0.69 log units) between middle value and limit.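

In this assay, compound 4 gives > 100000 nM, which is a limit and not a number. Methyl in place of trifluoromethyl gives an at least 22-fold higher number from compound 1 to compound 4 (1.35 log units; beyond the scatter), so the loss of measurable inhibition seen with the halogens fluoro and chloro at this position also occurs with a group that contains no halogen. The steps among compound 2, compound 3 and compound 4 cannot be read, as all three values are limits, and compound 4 shares its limit with compound 3: the limit of > 100000 nM in this assay, at which 2 of the 4 values shown sit.

As far as these compounds go, how fluoro, chloro and methyl truly compare remains unknown, and so far only trifluoromethyl, in compound 1, gives a measured number at this position. From the compounds shown here alone, whether another group here, such as methoxy, an amine or a carboxylic acid, would also give a measured number remains open.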